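Stilbene series: nitro to amino swap on the aryl ring

The source may report more compounds than this note shows. Statements on the series, on what has been measured and on what is new or still open speak of the compounds shown alone.

Compound 1 `COc1cc(/C=C/c2ccc(N(C)C)c([N+](=O)[O-])c2)cc(OC)c1OC` in a functional assay on HL-60 cells (Homo sapiens) for inhibition (on this read-out higher numbers stand for weaker inhibition and lower numbers for stronger inhibition), gives a limit of the assay, > 5000 nM, so compound 1 sits at the limit of > 5000 nM in this assay, at which 1 of the 3 values shown sits. Compound 2 `COc1cc(/C=C/c2ccc(N(C)C)c(N)c2)cc(OC)c1OC` differs from compound 1 by amino in place of nitro on an aromatic carbon, and in this assay compound 2 gives 1520 nM. For the measured compounds named here, the step of an at least 3.2-fold lower number from compound 1 to compound 2 (0.51 log units; beyond the scatter) is the only measured pair that differs in one place.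

Compound 3 `COc1cc(/C=C/c2ccc3ccccc3c2)cc([N+](=O)[O-])c1OC` in this assay gives a limit of the assay, > 10000 nM, so compound 3 sits at the limit of > 10000 nM in this assay, at which 1 of the 3 values shown sits. How the core of compound 3 differs from the core of compound 1 is not broken down here.

Compound 4 `COc1cc(/C=C/c2ccc3ccccc3c2)cc(N)c1OC` has not yet been measured in this assay. It differs from compound 3 by amino in place of nitro on an aromatic carbon, the same kind of change as from compound 1 to compound 2, though the place is not the same: in compound 2 the amino group stands ortho to a dimethylamino group and meta to a large group, whereas in compound 4 it stands ortho to a methoxy group, meta to a large group and meta to a methoxy group.

Resting on the step of an at least 3.2-fold lower number from compound 1 to compound 2 (0.51 log units; beyond the scatter) for compound 2, the step of an at least 2.5-fold lower number from compound 3 to compound 4 (0.39 log units; beyond the scatter) is expected to be of a similar direction. Compound 4 is therefore estimated at 4000 nM in this assay, expected to fall between 1000 nM and 15000 nM, with a real chance that the assay again reports only a limit.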

Compound 4, half-maximal inhibitory concentration: 3150 nM
Beside the measured number, compound 4's estimate is 1.3-fold (0.10 log units) above it; low and high end bracket the measured number.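

In this assay, amino in place of nitro on an aromatic carbon again gives a lower number, an at least 3.1-fold lower number from compound 3 to compound 4 (0.50 log units; beyond the scatter), so the direction of the change carries over from the core of compound 1 to the core of compound 3, with the two steps set side by side as follows: the same change on two cores in this assay, an at least 3.2-fold lower number (0.51 log units; beyond the scatter) from compound 1 to compound 2 and an at least 3.1-fold lower number (0.50 log units; beyond the scatter) from compound 3 to compound 4; the limit leaves it open whether they differ. The nitro member of the new pair, compound 3, is read only as a limit of the assay: the limit of > 10000 nM in this assay, at which 1 of the 4 values shown sits. The nitro member of the earlier pair, compound 1, is also read only as a limit of the assay, so these notes show a shared direction on two cores but neither the full size of the change on either core nor whether the two sizes match: the limit of > 5000 nM in this assay, at which 1 of the 4 values shown sits.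

The compounds shown pair only nitro with amino, on two cores and with the amino group in a different place on each, leaving open how far the direction holds on any further core or at any other place on these two. They also leave open whether a methylamino group, a hydroxyl group or an acetamide in the same place would give numbers in line with those of the amino compounds, compound 2 and compound 4.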